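The source may report more compounds than this note shows. Statements on the series, on what has been measured and on what is new or still open speak of the compounds shown alone.

Compound 1 `O=c1[nH]c(-c2ccccc2)cn2c(=O)n(-c3ccccc3)nc12` gives 96 nM in an assay on cells for displacement of a labelled ligand from adenosine receptor A3 (Homo sapiens), read by scintillation counting, with a stated time of 3 h; on this read-out higher numbers stand for weaker inhibition and lower numbers for stronger inhibition.
Compound 2 `Nc1nc(-c2ccc(O)cc2)cn2c(=O)n(-c3ccccc3)nc12` gives 53 nM in this assay.

Both compounds share the same core, and they differ in the groups attached to it. On the numbers shown, compound 2 and compound 1 lie so close together in this assay that the gap between them is within the usual scatter of repeated measurements, so neither can be called stronger than the other.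

Compound 3 `CC(C)Oc1ccc(-c2cn3c(=O)n(-c4ccccc4)nc3c(N)n2)cc1` keeps everything in compound 2 except one point: isopropyl in place of hydrogen on an oxygen on an aromatic ring. For the measured compounds named here, no pair of measured compounds in this set differs in a single place, so there is no measured step to lean on for this change. With only the two values above, and with compound 2 at 53 nM as the starting point, the expectation is that the step from compound 2 to compound 3 stays within the scatter, with no clear direction, so a 1.0-fold higher number from compound 2 to compound 3 (0.02 log units; within the scatter) is expected. Compound 3 is therefore estimated at 55 nM, with a likely range from 15 nM to 200 nM.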

Compound 3, inhibition constant: > 30000 nM
Compound 3: a limit, no number; the forecaster's own chance of this, stated with the estimate: 5%; middle value at least 540-fold (2.73 log units) from the limit.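

For the compounds shown here, this is the first measured step in the set that changes a single place, since no earlier pair differed in only one. Going from hydroxy to isopropoxy on the aromatic ring gives an at least 560-fold higher number from compound 2 to compound 3 (2.75 log units; beyond the scatter), so this oxygen is a place where one change can have a large effect in this assay, and here the change costs nearly all measurable inhibition. The result for compound 3 is a limit of the assay and not a number: the limit of > 30000 nM in this assay, at which 1 of the 3 values shown sits.

The compounds shown leave open whether this loss is specific to isopropyl or follows from putting any carbon group on this oxygen, and a smaller methyl group or a longer chain such as butyl on the same oxygen would help to separate these two readings. They also leave open whether the hydroxy hydrogen itself matters, which an amine or a fluorine in place of the hydroxy would test, and a single step cannot say why the number moves so far.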